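The compounds below may be only part of what the source reports. "The series", "measured", "known", "first", "only" and "open" are said of these compounds alone.

Measured compounds in this series:

compound 1 `O=C(CI)NCCCCCCCCNc1ncnc2c1ncn2[C@@H]1O[C@H](COP(=O)(O)OP(=O)(O)OP(=O)(O)O)[C@@H](O)[C@H]1O` — 35%
compound 2 `O=C(CI)NCCC(=O)NCCCCCCNc1ncnc2c1ncn2[C@@H]1O[C@H](COP(=O)(O)OP(=O)(O)OP(=O)(O)O)[C@@H](O)[C@H]1O` — 0%
compound 3 `O=C(CI)NCCCC(=O)NCCCCCCNc1ncnc2c1ncn2[C@@H]1O[C@H](COP(=O)(O)OP(=O)(O)OP(=O)(O)O)[C@@H](O)[C@H]1O` — 0%

All three numbers come from an assay on isolated protein for inhibition of hexokinase-1 (Rattus norvegicus), with a stated time of 6 h, tested at 10 mM; on this read-out lower numbers stand for less inhibition and higher numbers for more inhibition at the one concentration tested (going by the name of the read-out). Compound 3 stands level with compound 2, no change at the digits printed from compound 2 to compound 3 (within the scatter), and the two together are the lowest of the three values; the furthest is compound 1, with a number 35 percentage points lower from compound 1 to compound 3 (beyond the scatter) separating them.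

Compound 4 `O=C(CI)NCCCCCCCNc1ncnc2c1ncn2[C@@H]1O[C@H](COP(=O)(O)OP(=O)(O)OP(=O)(O)O)[C@@H](O)[C@H]1O` is not yet measured. It differs from compound 3 by a group of 6 heavy atoms (3 carbon, 1 nitrogen, 1 oxygen, 1 iodine; no ring) in place of a group of 11 heavy atoms (6 carbon, 2 nitrogen, 2 oxygen, 1 iodine; no ring), on a saturated chain carbon, six bonds along the chain from a nitrogen on an aromatic ring. Within the data shown here, the group that enters is of the same kind as the one carried by compound 1, so compound 4 resembles compound 1 more closely than compound 3 does, though with a shorter saturated chain. Among the measured compounds shown here, the steps that bear on this change are a number 35 percentage points lower from compound 1 to compound 2 (beyond the scatter) and a number 35 percentage points lower from compound 1 to compound 3 (beyond the scatter), both large and both in the direction of less inhibition when the larger group enters; the move to compound 4 undoes most of that change. A step upward beyond the scatter is therefore expected in this assay, though somewhat smaller than the full reversal, since the chain of compound 4 is not that of compound 1.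

For compound 4 the estimate is 25%, with a range from 5% to 45%, meaning an expected step of a number 25 percentage points higher from compound 3 to compound 4 (beyond the scatter).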

Compound 4, a percentage reported as inhibition, at one concentration (the size of the read-out at that concentration, not a potency): 20%
Estimate against measurement, compound 4: 5 percentage points above, within the range that was stated.
By their numbers in this assay, from the lowest: compounds 2 and 3 (each within the scatter of the next); then compound 4; then compound 1.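

In this assay, putting (((iodomethyl)carbonyl)amino)methyl in place of the larger group gives a number 20 percentage points higher from compound 3 to compound 4 (beyond the scatter) and a number 20 percentage points higher from compound 2 to compound 4 (beyond the scatter), so inhibition at this position is not confined to compound 1 and also appears with a second purely saturated chain. Chain length now shows up as a separate variable: with ((iodomethyl)carbonyl)amino in place of (((iodomethyl)carbonyl)amino)methyl, seven bonds along the chain from a nitrogen on an aromatic ring, the series gives a number 15 percentage points lower from compound 1 to compound 4 (beyond the scatter), so compound 4 sits short of compound 1 while still standing clear of compound 2 and compound 3. The same one-carbon change to the chain does not read alike in the two chain types, so its effect cannot be carried from one to the other: the same change on two cores in this assay, no change at the digits printed (within the scatter) from compound 2 to compound 3 and a number 15 percentage points higher (beyond the scatter) from compound 4 to compound 1, 15 percentage points apart, beyond the scatter of two such steps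

Still open, from the compounds shown here alone, is whether a longer saturated chain than that of compound 1 would raise the number further, or whether the trend with chain length ends there. Also open, going by these compounds, is whether the reading depends on the iodine, which a chloromethyl carbonyl group on the same chain would test, and all of these readings are single-concentration percentages rather than potencies.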